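Urea series on the shared core: trifluoromethyl added to compound 3

This account rests on a few compounds, and the source may have more. Where it says the series, first, only, none or still open, it means among the compounds named here.

Measured so far:
- compound 1, `O=C(Nc1ccccc1)Nc1nnc(Sc2ncnc3scc(-c4ccncc4)c23)s1`, in a functional assay on HUVEC cells (Homo sapiens) for antiproliferative activity, read by MTT assay, with a stated time of 48 h (on this read-out lower numbers stand for stronger inhibition and higher numbers for weaker inhibition), gives 19300 nM
- compound 2, `Cc1cccc(NC(=O)Nc2nnc(Sc3ncnc4scc(-c5ccncc5)c34)s2)c1`, in this assay gives 12200 nM
- compound 3, `O=C(Nc1ccc(Cl)cc1)Nc1nnc(Sc2ncnc3scc(-c4ccncc4)c23)s1`, in this assay gives 11600 nM

Compound 3 sits with the other two in one band: a 1.7-fold lower number from compound 1 to compound 3 (0.22 log units; within the scatter) and a 1.1-fold lower number from compound 2 to compound 3 (0.02 log units; within the scatter), so no order among the three can be read from these numbers.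

Compound 4, `O=C(Nc1ccc(Cl)c(C(F)(F)F)c1)Nc1nnc(Sc2ncnc3scc(-c4ccncc4)c23)s1`, is compound 3 with one change: trifluoromethyl in place of hydrogen on an aromatic carbon. Among the measured compounds shown here, the steps that bear on this are the two earlier additions of a single group to the phenyl ring, a 1.6-fold lower number from compound 1 to compound 2 (0.20 log units; within the scatter) and a 1.7-fold lower number from compound 1 to compound 3 (0.22 log units; within the scatter), and the swap a 1.1-fold lower number from compound 2 to compound 3 (0.02 log units; within the scatter), each within the scatter. Substitution on this ring has so far moved this assay by no more than the scatter, with at most a slight lowering of the number. The same is expected here: a small lowering, not beyond the scatter, with no measured case pointing to more.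

For compound 4 the expected step is a 1.3-fold lower number from compound 3 to compound 4 (0.11 log units; within the scatter). Compound 4 is estimated at 9000 nM in this assay, in the range 4000 nM to 20000 nM.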

Compound 4, half-maximal inhibitory concentration: 18400 nM
The estimate for compound 4 lay 2.0-fold (0.31 log units) below the measured number, within the range that was stated.
By their numbers in this assay, from the lowest: compounds 3, 2, 4 and 1 (each within the scatter of the next).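

In this assay, among the compounds shown here, compound 4 is the first case with two groups on the phenyl ring of the urea, and adding trifluoromethyl ortho to a chloro group gives a 1.6-fold higher number from compound 3 to compound 4 (0.20 log units; within the scatter). The wider comparisons, a 1.5-fold higher number from compound 2 to compound 4 (0.18 log units; within the scatter) and a 1.0-fold lower number from compound 1 to compound 4 (0.02 log units; within the scatter), also stay inside the scatter, so even this entry of 4 heavy atoms separates compound 4 from none of compounds 1, 2 and 3, and the direction of the step cannot be read. Nothing further is available to interpret this result.

Open, from the compounds shown here alone, is whether any change on this ring can move the number in this assay beyond the scatter. An amine, a carboxylic acid or a longer chain at this position could test this, and the compounds shown do not indicate what any of these would do.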